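A few compounds are considered here, and "the series" means these few. Any claim that something is new, unique, unknown or untested is made for them only; others in the source may bear on it.

Measured in a functional assay on the whole organism (strain Sprague-Dawley) for inhibition, with Rattus norvegicus as the target, with a stated time of 10 min; a lower number here means that less compound is needed, a higher number that more compound is needed for the effect:
compound 1 `CCOc1ccc(OC)cc1-c1ncc(C(=O)O)c(=O)[nH]1` gives 0.2 mg/kg
compound 2 `CCCOc1ccc(OC)cc1-c1ncc(C(=O)O)c(=O)[nH]1` gives 0.3 mg/kg
compound 3 `CCOC(=O)c1cnc(-c2ccccc2OC)[nH]c1=O` gives 10 mg/kg

Compound 3 stands well apart from the other two; the difference between its core and the core of compound 1 is not broken down here. Compound 4 `CCOC(=O)c1cnc(-c2ccccc2OCC)[nH]c1=O` is not yet measured. It differs from compound 3 by methyl in place of hydrogen on a saturated chain carbon bound to an oxygen on an aromatic ring. The same kind of change separates compound 1 from compound 2: methyl in place of hydrogen on a saturated chain carbon, two bonds along the chain from an oxygen on an aromatic ring. The places are not identical: in compound 1 the carbon lies two bonds along the chain from an oxygen on an aromatic ring, in compound 3 it is bound to an oxygen on an aromatic ring. In this assay that earlier change gave a 1.5-fold higher number from compound 1 to compound 2 (0.18 log units; within the scatter). A step of similar size, a 1.3-fold lower number from compound 3 to compound 4 (0.10 log units; within the scatter), is expected here, resting on the earlier step of a 1.5-fold higher number from compound 1 to compound 2 (0.18 log units; within the scatter) having stayed within the scatter. Compound 4 is estimated at 8 mg/kg, expected between 3 mg/kg and 25 mg/kg.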

Compound 4, dose for 50% inhibition: 2 mg/kg
Beside the measured number, compound 4's estimate is 4.0-fold (0.60 log units) above it; the whole stated range lies above it.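

In this assay, methyl in place of hydrogen on a saturated chain carbon bound to an oxygen on an aromatic ring gives a 5.0-fold lower number from compound 3 to compound 4 (0.70 log units; beyond the scatter). The size of the earlier step therefore did not carry over to this core, and the two steps differ: the same change on two cores in this assay, a 1.5-fold higher number (0.18 log units; within the scatter) from compound 1 to compound 2 and a 5.0-fold lower number (0.70 log units; beyond the scatter) from compound 3 to compound 4, 7.5-fold (0.88 log units) apart, beyond the scatter of two such steps. The methyl also sits at a different place in each pair, so these four compounds do not show whether the core, the place or both account for the gap, and one step on each core gives no general rule for the series.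

Going by these compounds, it remains open whether a butoxy chain on the core of compound 3 would continue this step or level off. On these data alone, the effect of an amine at the end of that chain is also open.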